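The source may hold more compounds than are shown below. What is called first, only, known or untested is meant among the compounds shown, and "the series" means these compounds.

In a functional assay on HCT-116 cells (Homo sapiens) for inhibition, read by CCK-8 assay, with a stated time of 72 h, tested at 2 uM (a lower number here means less inhibition of growth, a higher number more inhibition of growth at the concentration tested), compound 1 (`Nc1ccccc1NC(=O)/C=C/c1ccc(CSc2cccc(F)c2)cc1`) gives 7.95%. Compound 2 (`CCc1ccc(SCc2ccc(/C=C/C(=O)Nc3ccccc3N)cc2)cc1`) gives 3.29%, and compound 3 (`Cc1ccc(SCc2ccc(/C=C/C(=O)Nc3ccccc3N)cc2)cc1`) gives 6.23%. Compound 3 cannot be told apart from the other two, as the readings show a number 1.7 percentage points lower from compound 1 to compound 3 (within the scatter) and a number 2.9 percentage points higher from compound 2 to compound 3 (within the scatter).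

The next compound, compound 4 (`Nc1ccccc1NC(=O)/C=C/c1ccc(CSCCc2ccccc2)cc1`), has phenethyl in place of 4-methylphenyl on a sulfur. The measured changes at that sulfur bear most directly on this swap. They are a number 4.7 percentage points lower from compound 1 to compound 2 (within the scatter) and a number 1.7 percentage points lower from compound 1 to compound 3 (within the scatter), and both are small. The remaining step, a number 2.9 percentage points higher from compound 2 to compound 3 (within the scatter), is also small and alters the group on that sulfur as well. None of these steps tests a phenethyl group, so the range is kept wide.

On this evidence, the expected step is a number 0.2 percentage points lower from compound 3 to compound 4 (within the scatter), with no change expected beyond the scatter. Compound 4 is estimated at 6%, with an expected range from 0% to 14%.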

Compound 4, percent growth inhibition at one concentration: 18%
Estimate against measurement, compound 4: 12 percentage points below, outside the stated range (above it).
By their numbers in this assay, from the lowest: compounds 2, 3 and 1 (each within the scatter of the next); then compound 4.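

Phenethyl on the sulfur gives the first change at this position that lifts the reading in this assay beyond the scatter, with a number 11.8 percentage points higher from compound 3 to compound 4 (beyond the scatter) and a number 14.7 percentage points higher from compound 2 to compound 4 (beyond the scatter) and also a number 10.1 percentage points higher from compound 1 to compound 4 (beyond the scatter) for the same group. While 4-methylphenyl, 4-ethylphenyl and 3-fluorophenyl on that sulfur remain within the scatter of one another, phenethyl stands apart from all three, so this position does respond to a change of group, though the steps are modest. Nothing available gives a reason for this rise.

The compounds shown leave open whether a longer chain such as 3-phenylpropyl on the sulfur would raise the reading further or lower it. They also leave open whether the phenyl ring of phenethyl is needed at all, which a plain hexyl chain at the same place would address.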